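Fluorination of the shared core: compound 3 to compound 4

The compounds below may be only part of what the source reports. "The series", "measured", "known", "first", "only" and "open" are said of these compounds alone.

Compound 3 `N#C/C(=C\c1c[nH]c2ccccc12)C(=O)c1c[nH]c2ccccc12` is the unsubstituted member of the series. Going by the values given here, in a functional assay on MIA PaCa-2 cells (Homo sapiens) for cytotoxicity, read by WST assay, with a stated time of 48 h (a lower number here means a stronger inhibitor, a higher number a weaker inhibitor), compound 3 gives 36800 nM, the only numerical value among the three measured compounds. Compound 1 `COc1ccc2c(C(=O)/C(C#N)=C/c3c[nH]c4cc(F)ccc34)c[nH]c2c1` carries a methoxy group and a fluoro substituent; in this assay compound 1 gives > 50000 nM, which is a limit of the assay and not a number. Compound 2 `N#C/C(=C\c1c[nH]c2cc(F)ccc12)C(=O)c1c[nH]c2cc(F)ccc12` carries two fluoro substituents; in this assay compound 2 gives > 50000 nM, again a limit. The step from compound 1 to compound 2, a step that the two limits leave unreadable from compound 1 to compound 2, cannot be read. Two of the three values sit at the limit of > 50000 nM in this assay, at which 2 of the 3 values shown sit.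

Compound 4 `N#C/C(=C\c1c[nH]c2cc(F)ccc12)C(=O)c1c[nH]c2ccccc12` is not yet measured. Its difference from compound 3: fluoro in place of hydrogen on an aromatic carbon. Among the compounds with values here, no measured step isolates this single change; compound 3 without fluoro gives a number while compound 2 with two fluoro substituents gives only a limit, so some loss of potency is plausible but not established. The expected step from compound 3 to compound 4 in this assay is a 1.6-fold higher number from compound 3 to compound 4 (0.21 log units; within the scatter), towards weaker inhibition. Compound 4 is therefore estimated at 60000 nM, with a range from 25000 nM to 150000 nM, and a sizeable chance that only a limit is reported.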

Compound 4, half-maximal inhibitory concentration: 31600 nM
Beside the measured number, compound 4's estimate is 1.9-fold (0.28 log units) above it, within the range that was stated.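

Fluoro in place of hydrogen on this aromatic carbon, meta to a fused ring and para to a fused ring, is now isolated as a single change: in this assay it gives a 1.2-fold lower number from compound 3 to compound 4 (0.07 log units; within the scatter), so the read-out does not separate compound 3 from compound 4. On the other aromatic carbon that differs within the series, hydrogen in place of fluoro gives an at least 1.5-fold lower number from compound 2 to compound 4 (0.19 log units; that floor lies within the scatter) and hydrogen in place of methoxy gives an at least 1.5-fold lower number from compound 1 to compound 4 (0.19 log units; that floor lies within the scatter); each is only a floor that lies within the scatter, so neither step yet shows a real difference. Compound 1 and compound 2 are each held at a limit of the assay and not at a number: the limit of > 50000 nM in this assay, at which 2 of the 4 values shown sit.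

From the compounds shown here alone, it remains open how far the true values of compound 1 and compound 2 lie from that of compound 4, and so whether either substituent on that other carbon matters at all. On the carbon carrying the new fluoro, only hydrogen and fluoro are compared here, and an amine or a carboxylic acid there would show whether any group can move the number beyond the scatter.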